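Hydroxy on the aromatic ring of compound 1: working notes

The source may report more compounds than this note shows. Statements on the series, on what has been measured and on what is new or still open speak of the compounds shown alone.

Compound 1 (`C/C(=N\NC(=S)N1CCOCC1)c1ccccc1`) is the reference point for this step. In a functional assay on SMMC-7721 cells (Homo sapiens) for antiproliferative activity, read by MTT assay, with a stated time of 72 h (a lower number here means a stronger inhibitor, a higher number a weaker inhibitor), compound 1 gives > 64000 nM, which is a limit of the assay and not a number. Compound 2 (`C/C(=N\NC(=S)N1CCOCC1)c1cccc(O)c1`) gives > 64000 nM, which is likewise a limit. The evidence so far therefore consists only of the limit of > 64000 nM in this assay, at which 2 of the 2 values shown sit, and no number is available for either compound.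

Compound 3 (`C/C(=N\NC(=S)N1CCOCC1)c1ccc(O)cc1`) departs from compound 1 by hydroxy in place of hydrogen on an aromatic carbon. In words, this is hydroxy in place of hydrogen on an aromatic carbon, para to a large group.

Among the measured compounds shown here, one measured step bears on this change, the same kind of replacement in compound 2: a step that the two limits leave unreadable from compound 1 to compound 2. That step has no readable size and so offers no magnitude to carry over. It also shows no number emerging in this assay, so no step beyond the scatter is expected here.

The estimated step is a number no higher from compound 1 to compound 3 (the limit leaves the size open), with no direction favoured and a further limit the likeliest report. For compound 3 the estimated value is 64000 nM, with an expected range of 30000 nM to 100000 nM.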

Compound 3, half-maximal inhibitory concentration: > 64000 nM
Compound 3: a limit, no number; the forecaster's own chance of this, stated with the estimate: 80%; the middle value sits exactly at the limit.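

In this assay compound 3 gives > 64000 nM, a limit and not a number, so the step between compound 1 and compound 3 cannot be read. The series rests on one observation: the limit of > 64000 nM in this assay, at which 3 of the 3 values shown sit.

The compounds shown leave open whether any change to the shared core of compound 1 yields a number in this assay.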